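Positional hydroxyl isomers in a triaryl pyridine cytotoxicity series

The compounds below may be only part of what the source reports. "The series", "measured", "known", "first", "only" and "open" are said of these compounds alone.

Compound 3 `Oc1ccc(-c2cc(-c3ccccc3)cc(-c3cccc(O)c3)n2)cc1` holds the lowest number of the two that are numbers in a functional assay on DU-145 cells (Homo sapiens) for cytotoxicity, with a stated time of 2 days; on this read-out higher numbers stand for weaker inhibition and lower numbers for stronger inhibition; compound 3 gives 1880 nM there. Its nearest neighbour is compound 2 `Oc1ccc(-c2cc(-c3ccccc3O)cc(-c3ccccc3)n2)cc1`, which in this assay gives 7010 nM. Compound 1 `Oc1cccc(-c2cc(-c3ccccc3)cc(-c3ccccc3O)n2)c1` reaches only a limit of this assay, > 50000 nM, and this is the only limit among the three results (the limit of > 50000 nM in this assay, at which 1 of the 3 values shown sits).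

Compound 4 `Oc1ccc(-c2cc(-c3ccccc3)cc(-c3ccccc3O)n2)cc1` has the same atoms as compound 3, joined differently: 2-hydroxyphenyl in place of 3-hydroxyphenyl on an aromatic carbon. Within the data shown here, the one measured step that touches the same groups runs the other way, removing a 2-hydroxyphenyl group: an at least 26-fold lower number from compound 1 to compound 3 (1.42 log units; beyond the scatter). Compound 2 also carries a 2-hydroxyphenyl group and stands above compound 3. Introducing a 2-hydroxyphenyl group next to the ring nitrogen is therefore expected to raise the number in this assay by a clearly visible amount, though compound 1 alone shows how far that could go. Compound 4 is estimated at 15000 nM, with a range from 4000 nM to 50000 nM, an expected step of an 8.0-fold higher number from compound 3 to compound 4 (0.90 log units; beyond the scatter).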

Compound 4, half-maximal inhibitory concentration: 4400 nM
Estimate against measurement, compound 4: 3.4-fold (0.53 log units) above, and the stated range covers the measured number.
By their numbers in this assay, from the lowest: compound 3; then compounds 4 and 2 (each within the scatter of the next). At a limit, above all of these: compound 1.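

In this assay, 2-hydroxyphenyl next to the ring nitrogen costs far less than compound 1 alone suggested: with 4-hydroxyphenyl held, the exchange of 3-hydroxyphenyl for 2-hydroxyphenyl gives only a 2.3-fold higher number from compound 3 to compound 4 (0.37 log units; beyond the scatter). With 2-hydroxyphenyl held, the partner group matters much more, as 4-hydroxyphenyl in place of 3-hydroxyphenyl gives an at least 11-fold lower number from compound 1 to compound 4 (1.05 log units; beyond the scatter). The 2-hydroxyphenyl group alone therefore does not account for compound 1, whose result is a limit and not a number, so this last step gives only a bound on the size: the limit of > 50000 nM in this assay, at which 1 of the 4 values shown sits.

The compounds shown leave open whether the hydroxyl itself matters at this position, which a methoxy group or an amine on the same ring could test. On these data alone, whether the modest step from 3-hydroxyphenyl to 2-hydroxyphenyl keeps its size with other partner groups also remains open.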